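From Triazole to Imidazole on the Saturated Ring

This account rests on a few compounds, and the source may have more. Where it says the series, first, only, none or still open, it means among the compounds named here.

Compound 1 `COC(=O)/C=C(C)/C=C/C=C(C)/C=C/C1=C(C)C(n2cncn2)CCC1(C)C` has no single number in a functional assay on microsomes from T47D cells for inhibition of cytochrome P450 26A1 (Homo sapiens); on this read-out lower numbers stand for stronger inhibition and higher numbers for weaker inhibition: in this assay compound 1 gives "not determined" (no result reported). Compound 3 `COC(=O)/C=C(C)/C=C/C=C(C)/C=C/C1=C(C)C(n2ccnc2)CCC1(C)C` differs from it in one group (1H-imidazol-1-yl in place of 1H-1,2,4-triazol-1-yl on a saturated ring carbon). Compound 2 `COC(=O)/C=C(C)/C=C/C=C(C)/C=C/C1=C(C)[C@H](n2ccnc2)CCC1(C)C`, which also bears 1H-imidazol-1-yl, is measured: in this assay compound 2 gives 800 nM; 680 nM (2 entries), with repeat entries shown by the several entries of compound 2 in this assay, 800 nM; 680 nM (2 entries). Since compound 1 has no value, the size and direction of the step to compound 3 in this assay cannot be read from the data. Compound 3 is expected to give 1000 nM, within a range from 400 nM to 3000 nM.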

Compound 3, half-maximal inhibitory concentration: 40 nM
Estimate against measurement, compound 3: 25-fold (1.40 log units) above; the whole stated range lies above it.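

In this assay, for the compounds shown here, compound 1 carries no single number, so no step to compound 3 can be read. The compounds shown leave open how 1H-1,2,4-triazol-1-yl and 1H-imidazol-1-yl compare on the shared core.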